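Three sulfonyl variants, one untested amine

A few compounds are considered here, and "the series" means these few. Any claim that something is new, unique, unknown or untested is made for them only; others in the source may bear on it.

Values measured in an ADME assay on Vero cells (Chlorocebus sabaeus) for cytotoxicity, read by MTT assay (on this read-out lower numbers stand for higher toxicity in this test and higher numbers for lower toxicity in this test), follow.
- compound 1 (`Cn1nc(C(F)(F)F)cc1C(=O)Nc1ccc(S(=O)(=O)N2CCCCCCC2)cc1`) gives 16000 nM
- compound 2 (`Cn1nc(C(F)(F)F)cc1C(=O)Nc1ccc(S(=O)(=O)n2ccc3ccccc32)cc1`) gives 13000 nM
- compound 3 (`Cn1nc(C(F)(F)F)cc1C(=O)Nc1ccc(S(=O)(=O)NC2CCCCC2)cc1`) gives 15000 nM

In this assay compound 3 gives 15000 nM and cannot be separated from the other two. The steps that reach it are a 1.1-fold lower number from compound 1 to compound 3 (0.03 log units; within the scatter) and a 1.2-fold higher number from compound 2 to compound 3 (0.06 log units; within the scatter) and the remaining step is a 1.2-fold lower number from compound 1 to compound 2 (0.09 log units; within the scatter) so the three groups on the sulfonyl sulfur, though quite different, leave the numbers together.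

Compound 4 (`Cn1nc(C(F)(F)F)cc1C(=O)Nc1ccc(S(=O)(=O)N2CCC(N)CC2)cc1`) carries 4-aminopiperidin-1-yl in place of cyclohexylamino on a sulfonyl sulfur. Among the measured compounds shown here, no measured compound carries this group, so the steps above bear on the change only indirectly, and the range is kept wide. Given their small size, no step beyond the scatter is expected, in either direction. The expected change is a 1.2-fold lower number from compound 3 to compound 4 (0.06 log units; within the scatter) and no more than that. For compound 4 the estimate is 13000 nM with an expected range from 6000 nM to 28000 nM in this assay.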

Compound 4, half-maximal cytotoxic concentration: > 300000 nM
Compound 4 ended at the assay's limit; the forecaster's own chance of this, stated with the estimate: 10%; middle value at least 23-fold (1.36 log units) from the limit.
By their numbers in this assay, from the lowest: compounds 2, 3 and 1 (each within the scatter of the next). At a limit, above all of these: compound 4.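

Compound 4 separates from all three earlier compounds in this assay: the step of an at least 20-fold higher number from compound 3 to compound 4 (1.30 log units; beyond the scatter) and the step of an at least 23-fold higher number from compound 2 to compound 4 (1.36 log units; beyond the scatter) and also the step of an at least 18-fold higher number from compound 1 to compound 4 (1.27 log units; beyond the scatter) each lie beyond the scatter. The group on the sulfonyl sulfur, which had left the numbers together across three quite different groups, can therefore move this read-out strongly, even when one six-membered ring replaces another with the same count of heavy atoms. The value of compound 4 is a limit of the assay and not a number: the limit of > 300000 nM in this assay, at which 1 of the 4 values shown sits.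

The compounds shown do not separate the contribution of the amino group from that of the ring nitrogen, and a plain piperidin-1-yl or a 4-hydroxypiperidin-1-yl on the sulfonyl sulfur would be the groups to compare. Going by these compounds, whether a 3-aminopiperidin-1-yl or a 4-(dimethylamino)piperidin-1-yl would behave as 4-aminopiperidin-1-yl does also stays open.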